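A few compounds are considered here, and "the series" means these few. Any claim that something is new, unique, unknown or untested is made for them only; others in the source may bear on it.

Three compounds have been measured in a functional assay on KYSE-450 cells (Homo sapiens) for inhibition, read by CCK-8 assay, with a stated time of 48 h; on this read-out lower numbers stand for stronger inhibition and higher numbers for weaker inhibition:

compound 1 `COc1ccc(CN(C(=O)CSC(=S)N2CCN(C(=O)OC(C)(C)C)CC2)c2cc(OC)c(OC)c(OC)c2)cc1`: 250 nM
compound 2 `COc1ccc(CN(C(=O)CSC(=S)N2CCN(Cc3ccc(C(C)(C)C)cc3)CC2)c2cc(OC)c(OC)c(OC)c2)cc1`: 2140 nM
compound 3 `COc1ccc(CN(C(=O)CSC(=S)N2CCCC2)c2cc(OC)c(OC)c(OC)c2)cc1`: 13800 nM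

Of these three, compound 3 gives the highest number, at 13800 nM. Compound 4 `COc1ccc(CN(C(=O)CSC(=S)N2CCc3ccccc3C2)c2cc(OC)c(OC)c(OC)c2)cc1` has not yet been measured. It keeps the core of compound 3 but carries 1,2,3,4-tetrahydroisoquinolin-2-yl in place of pyrrolidin-1-yl on a thiocarbonyl carbon.

Going by the values given here, one measured step bears on this change: an 8.6-fold higher number from compound 1 to compound 2 (0.93 log units; beyond the scatter), with 4-(tert-butyl)benzyl in place of tert-butoxycarbonyl on an amine nitrogen in a ring. Compound 1 at 250 nM and compound 2 at 2140 nM both have a larger group on the thiocarbonyl carbon than compound 3, and both stand lower. Three compounds are few, and none of them carries the entering group, so a step of moderate size toward a lower number is expected in this assay, with wide uncertainty.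

The expected change is a 3.9-fold lower number from compound 3 to compound 4 (0.60 log units; beyond the scatter). For compound 4 the estimated value is 3500 nM. The expected range for compound 4 runs from 700 nM to 12000 nM.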

Compound 4, half-maximal inhibitory concentration: > 20000 nM
Compound 4 gave a limit, no number; the forecaster's own chance of this, stated with the estimate: 3%; middle value at least 5.7-fold (0.75 log units) from the limit.
By their numbers in this assay, from the lowest: compound 1; then compound 2; then compound 3. At a limit, above all of these: compound 4.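

In this assay compound 4 gives > 20000 nM, which is a limit and not a number. Replacing pyrrolidin-1-yl with 1,2,3,4-tetrahydroisoquinolin-2-yl on the thiocarbonyl carbon gives an at least 1.4-fold higher number from compound 3 to compound 4 (0.16 log units; that floor lies within the scatter), so this step fixes only a floor and not the true size of the change. The earlier compounds shown here suggested that a larger group at this place goes with a lower number, as in compound 1 and compound 2, but compound 4 goes against that reading, so size alone does not set the outcome here. The compounds shown leave open how a plain piperidin-1-yl or a morpholin-4-yl would stand on the thiocarbonyl carbon. They therefore also leave open whether the aromatic ring of the entering group matters for this result.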